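The source may report more compounds than this note shows. Statements on the series, on what has been measured and on what is new or still open speak of the compounds shown alone.

Measured so far in a functional assay on trachea (Cavia porcellus); a higher number here means a weaker inhibitor, a lower number a stronger inhibitor:
Compound 1, `CCCN1CC[C@@]2(OC)OC(N)=C(C#N)[C@@H](c3ccc(Cl)cc3Cl)[C@@H]2C1`: 35500 nM
Compound 2, `CO[C@@]12CCN(Cc3ccccc3)C[C@H]1[C@H](c1ccc(Cl)cc1Cl)C(C#N)=C(N)O2`: 18300 nM
Compound 3, `CCCN1CC[C@@]2(OC)OC(N)=C(C#N)[C@@H](c3ccc(OC)cc3)[C@@H]2C1`: 21300 nM

Compound 1 and compound 2 differ in one place, (phenyl in place of ethyl on a saturated chain carbon bound to an amine nitrogen in a ring), and this gave a 1.9-fold lower number from compound 1 to compound 2 (0.29 log units; within the scatter). Compound 1 and compound 3 differ in their cores: 4-methoxyphenyl in place of 2,4-dichlorophenyl on a saturated ring carbon, which gave a 1.7-fold lower number from compound 1 to compound 3 (0.22 log units; within the scatter).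

Compound 4, `COc1ccc([C@@H]2C(C#N)=C(N)O[C@]3(OC)CCN(Cc4ccccc4)C[C@@H]23)cc1`, is not yet measured. It differs from compound 3 by phenyl in place of ethyl on a saturated chain carbon bound to an amine nitrogen in a ring, the same change as between compound 1 and compound 2, made at the same place; among these compounds it occurs two times in all. Among the measured compounds shown here, compound 4 is expected to show a 1.9-fold lower number from compound 3 to compound 4 (0.29 log units; within the scatter) in this assay, because a 1.9-fold lower number from compound 1 to compound 2 (0.29 log units; within the scatter) was seen for the one earlier instance of this change, a step within the scatter. The estimate for compound 4 in this assay is 11000 nM.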

Compound 4, half-maximal inhibitory concentration: 23100 nM
Beside the measured number, compound 4's estimate is 2.1-fold (0.32 log units) below it; the measured number falls inside the stated range.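

In this assay, the change from propyl to benzyl, now made on the core carrying 4-methoxyphenyl, gave a 1.1-fold higher number from compound 3 to compound 4 (0.04 log units; within the scatter), and this does not differ beyond the scatter from its earlier instance: the same change on two cores in this assay, a 1.9-fold lower number (0.29 log units; within the scatter) from compound 1 to compound 2 and a 1.1-fold higher number (0.04 log units; within the scatter) from compound 3 to compound 4, 2.1-fold (0.32 log units) apart, within the scatter of two such steps The change from 2,4-dichlorophenyl to 4-methoxyphenyl, now made with benzyl in place of propyl, gave a 1.3-fold higher number from compound 2 to compound 4 (0.10 log units; within the scatter), and this also agrees with its earlier instance: the same change on two cores in this assay, a 1.7-fold lower number (0.22 log units; within the scatter) from compound 1 to compound 3 and a 1.3-fold higher number (0.10 log units; within the scatter) from compound 2 to compound 4, 2.1-fold (0.32 log units) apart, within the scatter of two such steps All four steps lie within the scatter, which shows that neither change clearly moves the number on these cores, but does not show that a step of real size would carry from one core to another.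

As far as these compounds go, it remains open whether a different group in place of propyl or benzyl, such as a longer chain or a chain ending in a carboxylic acid, would give a step beyond the scatter.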